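A few compounds are considered here, and "the series" means these few. Any claim that something is new, unique, unknown or untested is made for them only; others in the source may bear on it.

Compound 1, `CCOC(=O)C(=O)CC(=O)/C=C/c1cn(CCC(C)C)c2ccccc12`, is the reference point of this set. In an assay on isolated protein for inhibition of DNA nucleotidylexotransferase (Homo sapiens), read by scintillation counting, with a stated time of 10 min (a higher number here means a weaker inhibitor, a lower number a stronger inhibitor), compound 1 gives > 40 uM, which is a limit of the assay and not a number. Compound 2, `CCOC(=O)C(=O)CC(=O)/C=C/c1cn(-c2ccc(O)cc2)c2ccccc12`, carries 4-hydroxyphenyl in place of isopentyl on the aromatic nitrogen. In this assay compound 2 gives > 40 uM, again a limit rather than a number. Compound 3, `CCOC(=O)C(=O)CC(=O)/C=C/c1cn(CC(=O)N2CCOCC2)c2ccccc12`, carries (morpholin-4-yl)carbonyl in place of isobutyl on a saturated chain carbon bound to the aromatic nitrogen. In this assay compound 3 gives > 40 uM, also a limit. The steps among these three, a step that the two limits leave unreadable from compound 1 to compound 2, a step that the two limits leave unreadable from compound 1 to compound 3 and a step that the two limits leave unreadable from compound 2 to compound 3, cannot be sized because of the limit of > 40 uM in this assay, at which 3 of the 3 values shown sit.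

Compound 4, `CC(C)CCn1cc(/C=C/C(=O)CC(=O)C(=O)O)c2ccccc21`, differs from compound 1 elsewhere: hydrogen in place of ethyl on an oxygen next to a carbonyl group. Every measured step concerns the group on the aromatic nitrogen, so none of them bears on this change, and no direction can be read from them. Among the measured compounds shown here, the writer therefore expects only that the step from compound 1 to compound 4 is an at least 1.3-fold lower number from compound 1 to compound 4 (0.12 log units; that floor lies within the scatter), with wide uncertainty in either sense. Compound 4 is estimated at 30 uM, within a range from 5 uM to 100 uM.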

Compound 4, concentration for 50% inhibition: 16.3 uM
The estimate for compound 4 lay 1.8-fold (0.26 log units) above the measured number; the range from low to high includes it.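

Among the compounds shown here, compound 4 is the first compound in this set to give a number and not a limit in this assay: with carboxy in place of ethoxycarbonyl, compound 4 gives 16.3 uM. For the compounds shown here, the change of ethyl to hydrogen on an oxygen next to a carbonyl group is an at least 2.4-fold lower number from compound 1 to compound 4 (0.38 log units; beyond the scatter), the only readable step so far, whereas the steps among compound 1, compound 2 and compound 3, all of which concern the group on the aromatic nitrogen, cannot be read. This step is a floor and not a full size because one of its two ends is a limit: the limit of > 40 uM in this assay, at which 3 of the 4 values shown sit.

The compounds shown leave open whether the same change would also yield a number with 4-hydroxyphenyl or ((morpholin-4-yl)carbonyl)methyl on the aromatic nitrogen, as in compound 2 and compound 3. They also leave open how an amide or a methyl ester in place of the carboxy group of compound 4 would compare, and how a longer chain in place of isopentyl would read once the carboxy group is present.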